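The compounds below may be only part of what the source reports. "The series", "measured", "known", "first", "only" and "open" are said of these compounds alone.

Compound 3 `O=C(c1ccccc1)N1N=C(c2cc3ccccc3oc2=O)CC1c1ccccc1` is one of three compounds tested in a functional assay on MGC-803 cells (Homo sapiens) for cytotoxicity, read by MTT assay, with a stated time of 48 h (on this read-out higher numbers stand for weaker inhibition and lower numbers for stronger inhibition), where compound 3 gives 12700 nM. That places compound 3 second highest of the three numbers: compound 1 `CCN(CC)CC(=O)N1N=C(C)CC1c1ccccc1OC(C)=O` gives 29500 nM, and compound 2 `CC(=O)Oc1ccccc1C1CC(C)=NN1C(=O)CN1CCC(C(C)=O)CC1` gives 4120 nM, with compound 3 between them. Among the measured compounds shown here, the only step measured between neighbours, a 7.2-fold lower number from compound 1 to compound 2 (0.85 log units; beyond the scatter), concerns a change of the amine on a saturated chain carbon bound to a carbonyl carbon, and it does not cover the change now in question.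

Compound 4 `CC1CCCCN1CC(=O)N1N=C(c2cc3ccccc3oc2=O)CC1c1ccccc1` differs from compound 3 in one place: (2-methylpiperidin-1-yl)methyl in place of phenyl on a carbonyl carbon. For the measured compounds named here, no measured pair shows a phenyl on a carbonyl carbon traded for an amine-bearing chain, so the direction of the step rests on little. Compounds 1 and 2 both carry such an amine-bearing chain on the carbonyl, and their numbers bracket that of compound 3. Compound 4 is therefore expected to stay near compound 3, with an estimated step of a 1.6-fold lower number from compound 3 to compound 4 (0.20 log units; within the scatter), and the estimate for compound 4 in this assay is 8000 nM, within 2500 nM to 30000 nM.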

Compound 4, half-maximal inhibitory concentration: "not active" (no number reported)
No number was reported for compound 4; no gap can be computed for the estimate.
By their numbers in this assay, from the lowest: compound 2; then compound 3; then compound 1.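

Among the compounds shown here, compound 4 is reported only as "not active", with no number, so no step from compound 3 to compound 4 can be read. Nothing measured here accounts for this result. From the compounds shown here alone, what stays open is how far compound 4 lies from compound 3 on this read-out.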